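Swapping chloro for methoxy on the aryl ring

This account rests on a few compounds, and the source may have more. Where it says the series, first, only, none or still open, it means among the compounds named here.

Compound 1 `Nc1cccc(-c2cn3c(-c4ccc(Cl)cc4)csc3n2)c1` was tested in a functional assay on CCRF-CEM cells (Homo sapiens) for inhibition, read by cell counting, with a stated time of 3 days (a higher number here means a weaker inhibitor, a lower number a stronger inhibitor), where compound 1 gives 21000 nM. Of the two numbers on hand this is the highest, so compound 1 is the weaker of the two measured inhibitors. Its nearer neighbour is compound 2 `C=C(Br)C(=O)Nc1cccc(-c2cn3nc(Cc4cccc(OC)c4)sc3n2)c1`, which in this assay gives 3100 nM; the gap between the two lies beyond the usual scatter of repeated measurements. Compound 3 `Nc1cccc(-c2cn3nc(-c4ccc(F)cc4)sc3n2)c1` yields only a limit in this assay, recorded as >= 250000 nM, so no number is known for it. That entry is the limit of >= 250000 nM in this assay, at which 1 of the 3 values shown sits.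

Compound 4 `COc1ccc(-c2csc3nc(-c4cccc(N)c4)cn23)cc1` has not been measured. It differs from compound 1 in one place: methoxy in place of chloro on an aromatic carbon. Going by the values given here, no measured pair shows this exact change on the shared core, so there is no direct guide to its size. Compound 2 also carries a methoxy, but on a different core, and its value alone cannot be read as the effect of this swap. The step from compound 1 to compound 4 is therefore expected to stay within the scatter, with no clear direction: a 1.1-fold lower number from compound 1 to compound 4 (0.02 log units; within the scatter). Compound 4 is estimated at 20000 nM, with a likely range from 6000 nM to 70000 nM.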

Compound 4, half-maximal inhibitory concentration: 6100 nM
Estimate against measurement, compound 4: 3.3-fold (0.52 log units) above; measured number inside the range.
By their numbers in this assay, from the lowest: compounds 2 and 4 (each within the scatter of the next); then compound 1. At a limit, above all of these: compound 3.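

The swap of chloro for methoxy on the shared core now has a direct reading: on an aromatic carbon of the six-membered ring, para to a large group, it gives a 3.4-fold lower number from compound 1 to compound 4 (0.54 log units; beyond the scatter) in this assay, a modest step. The earlier compounds shown here could not show this, since none of them formed a pair differing in this one place, so this position is now known to accept methoxy, with its two heavy atoms and one hydrogen-bond acceptor, in place of chloro, with its one heavy atom and no acceptor, without the number rising. Why the number falls remains unexplained, as nothing measured for these compounds bears on the cause of this step.

Going by these compounds alone, a single swap gives only one step at this position, so it cannot show whether the size of the group or the presence of the acceptor matters more. A hydroxyl, an amine or a longer chain such as ethoxy at the same place would help to separate the two, and the same swap on the core of compound 3 would show whether the step carries over to another core.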